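The source may report more compounds than this note shows. Statements on the series, on what has been measured and on what is new or still open speak of the compounds shown alone.

Compound 1 `COc1ccc(C(=O)/C=C/c2ccc(OC)c(OC)c2)c(O)c1`, compound 2 `COc1ccc(C(=O)/C=C/c2ccc(OC)c(OC)c2OC)c(O)c1` and compound 3 `COc1ccc(OC)c(CCC(=O)c2cccc(O)c2)c1` were all tested in an ADME assay on RAW264.7 cells (Mus musculus) for cytotoxicity, read by MTT assay, with a stated time of 24 h, tested at 2.5 ug/mL; a lower number here means a stronger effect, a higher number a weaker effect of the compound at the concentration tested. In this assay compound 1 gives 92.6%. Compound 2 gives 96.6% in this assay. Compound 3 gives 96.8% in this assay. Going by the values given here, compound 2 therefore sits among three numbers that all lie within the usual scatter of one another, so no compound can be told apart from the others on these figures; the cells survive largely untouched at the concentration used in every case.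

The unmeasured compound 4 `COc1ccc(C(=O)/C=C/c2cccc(OC)c2OC)c(O)c1` differs from compound 2 in a single place: hydrogen in place of methoxy on an aromatic carbon. Among the compounds with values here, the one measured step that bears on this kind of change runs the other way, adding a methoxy group rather than removing one: a number 4 percentage points higher from compound 1 to compound 2 (within the scatter). Adding a methoxy group on an aromatic carbon thus made no difference beyond the scatter, and removing one is expected to behave the same way.

The expected step in this assay from compound 2 to compound 4 is accordingly a number 1.6 percentage points lower from compound 2 to compound 4 (within the scatter), nothing beyond the scatter. Compound 4 is estimated to give 95% in this assay, with a likely range from 86% to 100%.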

Compound 4, a percentage reported as activity, at one concentration (the size of the read-out at that concentration, not a potency): 72.9%
Beside the measured number, compound 4's estimate is 22.1 percentage points above it; the measured number lies below the stated range.
By their numbers in this assay, from the lowest: compound 4; then compounds 1, 2 and 3 (each within the scatter of the next).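

In this assay, replacing the methoxy group that sits para to a large group with hydrogen gives a number 23.7 percentage points lower from compound 2 to compound 4 (beyond the scatter), so in this series the read-out responds to what occupies this carbon, and compound 4 has the stronger effect at the concentration tested. The same kind of swap does not behave alike everywhere on this ring: the earlier change, on another aromatic carbon of the same ring, gave a number 4 percentage points higher from compound 1 to compound 2 (within the scatter), whereas the new step lies beyond the scatter, which shows that the position matters as well as the group. Nothing available explains why this one carbon should matter in this way.

From the compounds shown here alone, it remains open whether a fluorine atom, an ethoxy group or an amine on this carbon would keep the number close to that of compound 2 or bring it close to that of compound 4. Since the read-out comes from a single concentration, the compounds shown also leave open how compound 4 would behave at other concentrations, and so whether its stronger effect at the concentration tested would hold at other concentrations.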